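Hydroxymethyl to carboxy on the pyrazole-type core: second instance

The source may report more compounds than this note shows. Statements on the series, on what has been measured and on what is new or still open speak of the compounds shown alone.

Compound 1 `O=C(CCl)Nc1ccc(Cn2nc(-c3ccc(Oc4ccccc4)cc3)cc2CO)cc1` gives 400 nM in a functional assay on Rec1 cells (Homo sapiens) for inhibition, read by luminescence and CellTiter-Glo, with a stated time of 72 h; a higher number here means a weaker inhibitor, a lower number a stronger inhibitor. Compound 3 `C/C=C/C(=O)Nc1cccc(Cn2nc(-c3ccc(Oc4ccccc4)cc3)cc2CO)c1` gives 3400 nM in this assay; the difference between the cores of compound 1 and compound 3 is not broken down here. Compound 2 `C/C=C/C(=O)Nc1cccc(Cn2nc(-c3ccc(Oc4ccccc4)cc3)cc2C(=O)O)c1` gives 26000 nM, and the change carboxy in place of hydroxymethyl on an aromatic carbon made a step of a 7.6-fold higher number from compound 3 to compound 2 (0.88 log units; beyond the scatter). Compound 4 `O=C(CCl)Nc1ccc(Cn2nc(-c3ccc(Oc4ccccc4)cc3)cc2C(=O)O)cc1` carries the same change on the core of compound 1, (carboxy in place of hydroxymethyl on an aromatic carbon). Going by the values given here, because the earlier step of a 7.6-fold higher number from compound 3 to compound 2 (0.88 log units; beyond the scatter) lies beyond the scatter, a step of the same kind and size is expected from compound 1 to compound 4, a 7.5-fold higher number from compound 1 to compound 4 (0.88 log units; beyond the scatter), although only one earlier instance supports this. Compound 4 is therefore estimated at 3000 nM, between 1200 nM and 8000 nM, in this assay.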

Compound 4, half-maximal inhibitory concentration: 4000 nM
Estimate against measurement, compound 4: 1.3-fold (0.12 log units) below, within the range that was stated.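

In this assay, carboxy in place of hydroxymethyl gives a 10-fold higher number from compound 1 to compound 4 (1.00 log units; beyond the scatter), and the change carries over between the two cores with no difference in size that can be told apart: the same change on two cores in this assay, a 7.6-fold higher number (0.88 log units; beyond the scatter) from compound 3 to compound 2 and a 10-fold higher number (1.00 log units; beyond the scatter) from compound 1 to compound 4, 1.3-fold (0.12 log units) apart, within the scatter of two such steps. On these two cores, which differ from each other in more than one place, the step therefore behaves as roughly constant. Two pairs do not establish it for any further core, and they do not show what in the change produces the loss.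

Going by these compounds, it remains open how a primary carboxamide or a methyl ester would compare with hydroxymethyl and carboxy at this aromatic carbon. Also open, on these data alone, is whether the step would hold on a core carrying a different amide group.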